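The source may hold more compounds than are shown below. What is called first, only, known or untested is meant among the compounds shown, and "the series" means these compounds.

Measured so far:
compound 1 `O=C(NCCCCc1ccccc1)c1cccc(C2SCC(=O)N2c2ccccc2)c1`: 60%
compound 2 `COc1cc(F)ccc1N1C(=O)CSC1c1cccc(C(=O)NCCCCc2ccccc2)c1`: 63%

In a functional assay on 143B cells (Homo sapiens) for inhibition, read by CCK-8 assay, with a stated time of 72 h, tested at 1 uM (on this read-out lower numbers stand for less inhibition and higher numbers for more inhibition at the one concentration tested (going by the name of the read-out)), compound 2 gives 63%, and compound 1 gives 60%; the step of a number 3 percentage points higher from compound 1 to compound 2 (within the scatter) lies within the scatter, so the two numbers are not told apart by this assay.

Compound 3 `COc1ccc(N2C(=O)CSC2c2cccc(C(=O)NCCCCc3ccccc3)c2)c(OC)c1` differs from compound 2 in one place: methoxy in place of fluoro on an aromatic carbon. Among the measured compounds shown here, the only measured step, a number 3 percentage points higher from compound 1 to compound 2 (within the scatter), replaces the whole phenyl on the ring nitrogen at once and moved the read-out by less than the scatter. For the measured compounds named here, no measured pair exchanges a methoxy for a fluoro on that aromatic ring, so there is no direct precedent for this change. Given that the single relevant step stayed within the scatter, the expected step in this assay is a number 1 percentage points lower from compound 2 to compound 3 (within the scatter), that is, no shift beyond the scatter in either direction. Compound 3 is therefore estimated at 62%, with a range of 48% to 76%.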

Compound 3, a percentage reported as inhibition, at one concentration (the size of the read-out at that concentration, not a potency): 53%
Estimate against measurement, compound 3: 9 percentage points above, and the stated range covers the measured number.
By their numbers in this assay, from the lowest: compounds 3, 1 and 2 (each within the scatter of the next).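

In this assay methoxy in place of fluoro on the aromatic carbon para to a large group, meta to a methoxy group, gives a number 10 percentage points lower from compound 2 to compound 3 (within the scatter) and so does not separate the two groups at this position. Against the plain ring, 2,4-dimethoxyphenyl in place of phenyl gives a number 7 percentage points lower from compound 1 to compound 3 (within the scatter) and so this second substituted ring is also not told apart from phenyl, which the earlier step showed only for 4-fluoro-2-methoxyphenyl. No supporting data bear on this result.

As far as these compounds go, whether an amine, a carboxylic acid or a longer alkoxy chain on this aromatic carbon would give a step beyond the scatter remains open. With a single concentration per compound, any difference in potency among these compounds also remains open.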